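A few compounds are considered here, and "the series" means these few. Any claim that something is new, unique, unknown or untested is made for them only; others in the source may bear on it.

Measured so far in a functional assay on A549 cells (Homo sapiens) for antiproliferative activity, read by MTT assay, with a stated time of 72 h; a higher number here means a weaker inhibitor, a lower number a stronger inhibitor:
compound 1 `CCOc1ccc(-c2ccc3ncn(-c4cc(OC)c(OC)c(OC)c4)c3c2)cc1` gives 8550 nM.
compound 2 `COc1cc(-n2cnc3ccc(-c4ccc(C)cc4F)cc32)cc(OC)c1OC` gives > 10000 nM, a limit of the assay and not a number.
compound 3 `COc1cc(-n2cnc3ccc(-c4cccc(C)c4)cc32)cc(OC)c1OC` gives 3820 nM.

Compound 2 stands at the limit of this assay, with no number of its own (the limit of > 10000 nM in this assay, at which 1 of the 3 values shown sits). Compound 4 `COc1cc(-n2cnc3ccc(-c4ccc(F)cc4)cc32)cc(OC)c1OC` is still to be measured. The change from compound 2 to compound 4 is 4-fluorophenyl in place of 2-fluoro-4-methylphenyl on an aromatic carbon. Within the data shown here, two measured steps bear on this position. The step of an at least 1.1-fold higher number from compound 1 to compound 2 (0.06 log units; that floor lies within the scatter) and the step of an at least 2.6-fold lower number from compound 2 to compound 3 (0.41 log units; beyond the scatter) both leave compound 2 as the compound without a measured figure, while a 2.2-fold lower number from compound 1 to compound 3 (0.35 log units; beyond the scatter) puts compound 3 at the lowest number of the three. Both moves away from the 2-fluoro-4-methylphenyl group went towards lower numbers, so a lower number is expected for compound 4 as well, but only a small one, since compound 1, also carrying a single group on its phenyl ring, gives a high number in this assay. Compound 4 is expected to come in at 7000 nM, in the range 2500 nM to 20000 nM. The expected step is an at least 1.4-fold lower number from compound 2 to compound 4 (0.15 log units; that floor lies within the scatter), and it is estimated that this assay may again report only a limit for compound 4.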

Compound 4, half-maximal inhibitory concentration: 6740 nM
Compound 4: the middle estimate sits 1.0-fold (0.02 log units) above what was measured; low and high end bracket the measured number.
By their numbers in this assay, from the lowest: compounds 3, 4 and 1 (each within the scatter of the next, the first and the last beyond it). At a limit, above all of these: compound 2.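

In this assay, compound 4 shows that a single fluoro group on this phenyl ring reads much like the ethoxy group of compound 1, a 1.3-fold lower number from compound 1 to compound 4 (0.10 log units; within the scatter), and that 4-fluorophenyl also stays within the scatter of 3-methylphenyl, a 1.8-fold higher number from compound 3 to compound 4 (0.25 log units; within the scatter). Going by these compounds, the step from the 2-fluoro-4-methylphenyl group now has a second measured partner, an at least 1.4-fold lower number from compound 2 to compound 4 (0.17 log units; that floor lies within the scatter), but only its floor can be read, and the true size of the step remains unknown. Compound 2 remains a limit of the assay and not a number: the limit of > 10000 nM in this assay, at which 1 of the 4 values shown sits.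

Open, on these data alone, is whether 3-fluorophenyl or 4-methylphenyl would separate the identity of the group from its place on the ring. Also open is whether an amine or a carboxylic acid on this phenyl ring would shift the number beyond the scatter of these compounds.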